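The source may hold more compounds than are shown below. What is called first, only, known or untested is meant among the compounds shown, and "the series" means these compounds.

Measured so far:
- compound 1, `Cc1nc(N2CCC(N3CCCS3(=O)=O)CC2)nc2ccc(NC(=O)/C=C/c3ccc(OC(F)(F)F)cc3)cc12`: 85%
- compound 2, `Cc1nc(N2CCC(N3C(=O)CCC3=O)CC2)nc2ccc(NC(=O)/C=C/c3ccc(OC(F)(F)F)cc3)cc12`: "not determined" (no result reported)
- compound 3, `Cc1nc(N2CCC(N3CCCC3=O)CC2)nc2ccc(NC(=O)/C=C/c3ccc(Cl)cc3)cc12`: 50%

In an ADME assay on microsomes from liver (Homo sapiens) for metabolic stability, with a stated time of 30 min (a lower number here means that less of the compound is left, a higher number that more of the compound is left), compound 3 gives 50%, the lowest of the two numbers in hand. The nearest entry is compound 1, which in this assay gives 85%, a value well beyond the scatter above that of compound 3; compound 2 carries no number. Compound 1 and compound 3 differ in more than one place, so no single step can be read from that pair.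

Compound 4, `Cc1nc(N2CCC(N3CCCC3=O)CC2)nc2ccc(NC(=O)/C=C/c3ccc(OC(F)(F)F)cc3)cc12`, is not yet measured. From compound 3 it changes by trifluoromethoxy in place of chloro on an aromatic carbon, the same difference read one bond further out being 4-chlorophenyl to 4-(trifluoromethoxy)phenyl. Among the compounds with values here, no step between measured compounds isolates this change. Compound 1 also carries the trifluoromethoxy group and sits higher, but its other ring differs, so that pair cannot be credited to the aromatic substituent alone. The expectation for compound 4 is therefore a small step from compound 3, a number 5 percentage points higher from compound 3 to compound 4 (within the scatter), not clearly beyond the scatter in either direction. Compound 4 is estimated in this assay at 55%, within a range from 35% to 75%.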

Compound 4, percent of the compound remaining: 76%
Estimate against measurement, compound 4: 21 percentage points below; the measured number lies above the stated range.
By their numbers in this assay, from the lowest: compound 3; then compounds 4 and 1 (each within the scatter of the next).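

In this assay, within the data shown here, the change of 4-chlorophenyl to 4-(trifluoromethoxy)phenyl, on an aromatic carbon of the six-membered ring and para to a large group, gives a number 26 percentage points higher from compound 3 to compound 4 (beyond the scatter) and is the first step to isolate this position; the read-out responds to the aromatic substituent here, at least with the group of 6 heavy atoms held constant on the saturated ring carbon. With trifluoromethoxy held constant, exchanging the group of 7 heavy atoms on that saturated ring carbon for the group of 6 heavy atoms gives a number 9 percentage points lower from compound 1 to compound 4 (within the scatter) and so separates neither group from the other in this assay. Nothing in hand bears on why the aromatic exchange moves the number.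

Among these compounds, whether the trifluoromethoxy step carries over with the group of 7 heavy atoms on the saturated ring carbon remains open, since the series offers only this one pair for that change. Also open, as far as these compounds go, is how a trifluoromethyl, a methoxy or a nitrile would read on the same aromatic carbon, and how an amine or a carboxylic acid would read on the saturated ring carbon.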